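Methyl for trifluoromethyl, repeated on a second core

The source may report more compounds than this note shows. Statements on the series, on what has been measured and on what is new or still open speak of the compounds shown alone.

The series is read in a functional assay on HepG2 cells (Homo sapiens) for inhibition, read by MTT assay, with a stated time of 72 h; a higher number here means a weaker inhibitor, a lower number a stronger inhibitor. Compound 1 `CN(C(=O)NC(=O)c1ccc(Cl)cc1Cl)c1nc(C(F)(F)F)c(C(=O)N/N=C/c2ccc(C(F)(F)F)cc2)s1` gives 12.4 ug/mL in this assay. Compound 2 `Cc1nc(N(C)C(=O)NC(=O)c2ccc(Cl)cc2Cl)sc1C(=O)N/N=C/c1ccc(C(F)(F)F)cc1` differs from compound 1 by methyl in place of trifluoromethyl on an aromatic carbon. In this assay compound 2 reaches only a limit, > 100 ug/mL. The step is an at least 8.0-fold higher number from compound 1 to compound 2 (0.90 log units; beyond the scatter), and its size rests on (the limit of > 100 ug/mL in this assay, at which 1 of the 3 values shown sits).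

Compound 3 `CN(C(=O)NC(=O)c1c(F)cccc1F)c1nc(C(F)(F)F)c(C(=O)N/N=C/c2ccc(C(F)(F)F)cc2)s1` differs from compound 1 by 2,6-difluorophenyl in place of 2,4-dichlorophenyl on a carbonyl carbon. In this assay compound 3 gives 49.6 ug/mL, a step of a 4.0-fold higher number from compound 1 to compound 3 (0.60 log units; beyond the scatter).

Compound 4 `Cc1nc(N(C)C(=O)NC(=O)c2c(F)cccc2F)sc1C(=O)N/N=C/c1ccc(C(F)(F)F)cc1` is not yet measured. Within the data shown here, it differs from compound 3 by methyl in place of trifluoromethyl on an aromatic carbon, the same change at the same place as the one that separates compound 1 from compound 2. The expectation for compound 4 rests on compound 2, whose step was an at least 8.0-fold higher number from compound 1 to compound 2 (0.90 log units; beyond the scatter); carried onto the weaker compound 3, this change should again push the number past the limit of this assay, so compound 4 will most likely be reported only as a limit. The expected step, for compound 4, is a 5.0-fold higher number from compound 3 to compound 4 (0.70 log units; beyond the scatter). Compound 4 is estimated at 250 ug/mL, with a likely range from 90 ug/mL to 700 ug/mL.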

Compound 4, half-maximal inhibitory concentration: > 100 ug/mL
Compound 4: only a limit was reported; the forecaster's own chance of this, stated with the estimate: 80%; the middle value is on the limit's open side.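

In this assay compound 4 is reported only as a limit, > 100 ug/mL. Methyl in place of trifluoromethyl gives an at least 2.0-fold higher number from compound 3 to compound 4 (0.30 log units; that floor lies within the scatter), which is compatible with the change carrying over to the core of compound 3 in the same direction but does not establish it, as only a floor is available. The size of the change on the two cores cannot be compared, so nothing shows whether it is the same on both: the same change on two cores in this assay, an at least 8.0-fold higher number (0.90 log units; beyond the scatter) from compound 1 to compound 2 and an at least 2.0-fold higher number (0.30 log units; that floor lies within the scatter) from compound 3 to compound 4; the limit leaves it open whether they differ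

The compounds shown leave open what other groups would do on the aromatic carbon that carries trifluoromethyl, such as a nitrile, an amine or a longer chain. With methyl on that carbon, the step between compound 2 and compound 4 cannot be read, so the choice of 2,6-difluorophenyl or 2,4-dichlorophenyl on the carbonyl carbon remains unresolved on that core: the limit of > 100 ug/mL in this assay, at which 2 of the 4 values shown sit.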